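Series notes: swapping the amine substituent in compound 1

This account rests on a few compounds, and the source may have more. Where it says the series, first, only, none or still open, it means among the compounds named here.

In an ADME assay on A549 cells (Homo sapiens) for cytotoxicity, read by resazurin assay, with a stated time of 48 h (a lower number here means that less compound is tolerated, a higher number that more compound is tolerated), compound 1 `O=C(Nc1ccc(NCC2CCCC2)cc1Cl)c1cc(Cl)ccc1O` gives 21500 nM and stands second highest of the three numbers. Compound 3 `O=C(Nc1ccc(NCc2cc(F)cc(C(F)(F)F)c2)cc1Cl)c1cc(Cl)ccc1O` gives 30900 nM and compound 2 `O=C(Nc1ccc(NCc2cccc(C(F)(F)F)c2)cc1Cl)c1cc(Cl)ccc1O` gives 13300 nM; both gaps to compound 1 lie within the scatter.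

Compound 4 `CC(C)(CCO)Nc1ccc(NC(=O)c2cc(Cl)ccc2O)c(Cl)c1` differs from compound 1 by 3-hydroxy-1,1-dimethylpropyl in place of cyclopentylmethyl on a nitrogen on an aromatic ring. Within the data shown here, the step that touches the same nitrogen-bound carbon, a 1.6-fold lower number from compound 1 to compound 2 (0.21 log units; within the scatter), is the nearest precedent. Among the measured compounds shown here, the only step beyond the scatter, a 2.3-fold higher number from compound 2 to compound 3 (0.37 log units; beyond the scatter), concerns a fluoro on an aromatic carbon, not this substituent. For the measured compounds named here, no measured step introduces a hydroxyl, so the expectation for compound 4 is no step beyond the scatter, a 1.0-fold lower number from compound 1 to compound 4 (0.01 log units; within the scatter).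

Compound 4 is estimated at 21000 nM, within a range from 8000 nM to 55000 nM.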

Compound 4, half-maximal cytotoxic concentration: 170000 nM
Estimate against measurement, compound 4: 8.1-fold (0.91 log units) below; measured number above the stated range.
By their numbers in this assay, from the lowest: compounds 2, 1 and 3 (each within the scatter of the next, the first and the last beyond it); then compound 4.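

In this assay, among these compounds, this nitrogen substituent is the first position to show a large shift: 3-hydroxy-1,1-dimethylpropyl in place of cyclopentylmethyl gives a 7.9-fold higher number from compound 1 to compound 4 (0.90 log units; beyond the scatter). The change removes the ring, adds the hydroxyl and introduces the 1,1-dimethyl branching all at once, so this step cannot assign the shift to any one of them. No measurement shown bears on the cause of the shift.

On these data alone, the separate contributions of the hydroxyl and the branching remain open. A 3-hydroxypropyl chain and a 1,1-dimethylpropyl group on the same nitrogen would separate them.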